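From Compound 2 to Compound 3 at the Assay Limit

A few compounds are considered here, and "the series" means these few. Any claim that something is new, unique, unknown or untested is made for them only; others in the source may bear on it.

In a functional assay on HepG2 cells (Homo sapiens) for antiproliferative activity, read by MTT assay, with a stated time of 48 h (on this read-out higher numbers stand for weaker inhibition and lower numbers for stronger inhibition), compound 1 `CCn1c(C(=O)Nc2ccc(OC(F)(F)F)cc2)ccc1C(CC)(CC)c1ccc(OCCC(O)(CC)CC)c(C)c1` gives > 50000 nM, which is a limit and not a number. Compound 2 `CCOC(=O)C(CC(=O)OC)NC(=O)c1ccc(C(CC)(CC)c2ccc(OCCC(O)(CC)CC)c(C)c2)n1CC` gives > 50000 nM, again a limit. The whole record so far is the limit of > 50000 nM in this assay, at which 2 of the 2 values shown sit, so compound 2 has no exact standing. Within the data shown here, the one measured step, a step that the two limits leave unreadable from compound 1 to compound 2, therefore offers no size to carry forward. Compound 3 `CCn1c(C(=O)NC(CC(=O)O)C(=O)OC)ccc1C(CC)(CC)c1ccc(OCCC(O)(CC)CC)c(C)c1` differs from compound 2 by a single change on an amide-type nitrogen: a group of 9 heavy atoms (5 carbon, 4 oxygen; no ring) in place of a group of 11 heavy atoms (7 carbon, 4 oxygen; no ring), on an amide-type nitrogen. Neither measured compound gives a number in this assay, so nothing in the data points to a gain in inhibition, and compound 3 is expected to stay inactive at the limit. The expected step is a number no higher from compound 2 to compound 3 (the limit leaves the size open), with no change foreseen beyond the scatter. Compound 3 is estimated at 50000 nM, with an expected range from 25000 nM to 100000 nM.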

Compound 3, half-maximal inhibitory concentration: 10700 nM
Beside the measured number, compound 3's estimate is 4.7-fold (0.67 log units) above it; the measured number lies below the stated range.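

In this assay this place, on an amide-type nitrogen whose other neighbour is a carbonyl carbon, turns out to be able to move the read-out: the group of 9 heavy atoms, with 1 hydrogen-bond donor, replaces a group of 11 heavy atoms with none and gives an at least 4.6-fold lower number from compound 2 to compound 3 (0.66 log units; beyond the scatter). The same entering group, in place of the group holding a six-membered aromatic ring, gives an at least 4.6-fold lower number from compound 1 to compound 3 (0.66 log units; beyond the scatter). Among these compounds, compound 3 thus holds the only exact number so far, while the other two compounds stay at a limit: the limit of > 50000 nM in this assay, at which 2 of the 3 values shown sit.

Going by these compounds, the step from compound 1 to compound 2 cannot be read, and the full size of both new steps stays open. Also open, on these data alone, is which part of the entering group carries the gain, and what an amine or a longer chain on the same amide-type nitrogen would give.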